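Fluoro to methoxy on the para-substituted ring: compound 4

A few compounds are considered here, and "the series" means these few. Any claim that something is new, unique, unknown or untested is made for them only; others in the source may bear on it.

Compound 3 `CC(=O)c1cc(-c2ccc(F)cc2)cc2cc(-c3ccc(F)cc3)[nH]c12` gives 87400 nM in a functional assay on MCF7 cells (Homo sapiens) for cytotoxicity, read by MTT assay, with a stated time of 2 days (on this read-out higher numbers stand for lower toxicity in this test and lower numbers for higher toxicity in this test), the higher of the two numbers in hand; compound 1 `COc1ccc(-c2cc(C(C)=O)c3[nH]c(-c4ccccc4)cc3c2)cc1` gives 47800 nM, and the gap between these two lies within the scatter. Compound 2 `CC(=O)c1cc(-c2ccccc2)cc2cc(-c3ccc(F)cc3)[nH]c12` reaches only a limit, > 100000 nM, and so yields no number. For the measured compounds named here, the single measured step, an at least 1.1-fold lower number from compound 2 to compound 3 (0.05 log units; that floor lies within the scatter), is a floor set by the limit of > 100000 nM in this assay, at which 1 of the 3 values shown sits, and stays inside the scatter. Compound 4 `COc1ccc(-c2cc(C(C)=O)c3[nH]c(-c4ccc(F)cc4)cc3c2)cc1` arises from compound 3 by methoxy in place of fluoro on an aromatic carbon. Going by the values given here, no measured step covers methoxy in place of fluoro; compounds 1 and 3 differ at another ring, and their values sit within the scatter of each other. The expectation for compound 4 is therefore no step beyond the scatter, a 1.3-fold lower number from compound 3 to compound 4 (0.13 log units; within the scatter). Compound 4 is estimated at 65000 nM, with a range from 25000 nM to 150000 nM.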

Compound 4, concentration lethal to 50% of the cells: 16800 nM
Compound 4: the middle estimate sits 3.9-fold (0.59 log units) above what was measured; the whole stated range lies above it.
By their numbers in this assay, from the lowest: compound 4; then compounds 1 and 3 (each within the scatter of the next). At a limit, above all of these: compound 2.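

In this assay, for the compounds shown here, 4-methoxyphenyl in place of 4-fluorophenyl gives the first step at this position that clears the scatter: a 5.2-fold lower number from compound 3 to compound 4 (0.72 log units; beyond the scatter). Methoxy in place of hydrogen at the same position gives an at least 5.9-fold lower number from compound 2 to compound 4 (0.77 log units; beyond the scatter), a floor and not a measured size. Fluoro in place of hydrogen on the other ring, which gave no step beyond the scatter before, now gives a 2.8-fold lower number from compound 1 to compound 4 (0.45 log units; beyond the scatter) with methoxy present.

From the compounds shown here alone, compound 2 gives > 100000 nM, a limit, so whether the fluoro step differs between the two cores stays open. Also open, going by these compounds, is where a hydroxyl or an amine at this position would fall relative to methoxy.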